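Dropping the Terminal Vinyl From a Weak Diyne Ester

This account rests on a few compounds, and the source may have more. Where it says the series, first, only, none or still open, it means among the compounds named here.

Of the compounds shown here, three built around a conjugated diyne have been measured in a functional assay on SK-OV-3 cells (Homo sapiens) for cytotoxicity; a lower number here means that less compound is needed, a higher number that more compound is needed for the effect. Compound 1 `C=CCCCCCCCC#CC#CCOCC(=O)O`, a carboxylic acid, gives 4.88 ug/mL in this assay. Compound 3 `C=CCCCCCC#CC#C/C(O)=C/C(C)=O`, which carries a different polar end, gives 5.23 ug/mL in this assay. Compound 2 `C=CCCCCCCCC#CC#CCOCC(=O)OC` is the methyl ester of compound 1. For compound 2 the assay reports only a limit, > 30 ug/mL, rather than a number. Within the data shown here, the only single-point change measured so far is therefore an at least 6.1-fold higher number from compound 1 to compound 2 (0.78 log units; beyond the scatter), and one of the three values sits at the limit of > 30 ug/mL in this assay, at which 1 of the 3 values shown sits. Compound 2 thus stands at the weak end of everything measured.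

Compound 4 `CCCCCCCC#CC#CCOCC(=O)OC` keeps the methyl ester of compound 2 and changes only the far end of the chain: hydrogen in place of vinyl on a saturated chain carbon, seven bonds along the chain from a triple-bonded carbon. Among the measured compounds shown here, no measured step touches this part of the molecule, so nothing here sets a size or direction for the change. Compound 4 is expected to stay close to where compound 2 sits, at about 40 ug/mL in this assay, within a range of 15 ug/mL to 100 ug/mL, most likely again reported as a limit. The expected step is a step that the limit leaves unreadable from compound 2 to compound 4, meaning no change beyond the scatter is anticipated.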

Compound 4, concentration for half-maximal effect: 20.5 ug/mL
Estimate against measurement, compound 4: 2.0-fold (0.29 log units) above, within the range that was stated.
By their numbers in this assay, from the lowest: compounds 1 and 3 (each within the scatter of the next); then compound 4. At a limit, above all of these: compound 2.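

Among these compounds, this is the first measured change at the far end of the chain, and with hydrogen in place of vinyl the methyl ester gives a number in this assay rather than a limit. The step is an at least 1.4-fold lower number from compound 2 to compound 4 (0.16 log units; that floor lies within the scatter): the vinyl can go without the number rising, but no real gain can be claimed from this floor. The true size of the step stays unknown because compound 2 is held at a limit: the limit of > 30 ug/mL in this assay, at which 1 of the 4 values shown sits.

As far as these compounds go, it remains open whether the vinyl matters in the free acid, since compound 1 has no partner with hydrogen at this end. From the compounds shown here alone, how an amine or a longer saturated chain at this end would read also remains open.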